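The compounds below may be only part of what the source reports. "The series", "measured", "known", "first", "only" and "open" are said of these compounds alone.

Working notes on the series. The shared core of compound 1 `O=C(NO)c1ccc(NCc2nc(-c3cccnc3)nn2-c2ccccc2)cc1` is carried through the three measured compounds. In an assay on Sf9 cells for inhibition of protein deacetylase HDAC6 (Homo sapiens), read by fluorescence, with a stated time of 40 min, tested at 100 nM (a lower number here means less inhibition, a higher number more inhibition at the concentration tested (going by the name of the read-out)), compound 1 gives 57.7%, the lowest of the three numbers seen so far. Compound 2 `O=C(NO)c1ccc(NCc2nc(-c3ccccc3)nn2-c2cccc(Cl)c2)cc1` gives 62.3% in this assay, a value within the scatter of compound 1, so the two cannot be told apart. Compound 3 `O=C(NO)c1ccc(NCc2nc(-c3cccs3)nn2-c2ccc(O)cc2)cc1` gives 79.6% in this assay, a value beyond the scatter above compound 1. Going by the values given here, no pair of measured compounds differs in one place only, so no single change has yet been isolated.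

The next compound, compound 4 `O=C(NO)c1ccc(NCc2nc(-c3ccccc3Cl)nn2-c2ccccc2)cc1`, differs from compound 1 in one place: 2-chlorophenyl in place of pyridin-3-yl on an aromatic carbon. Among the compounds with values here, no comparable step has been measured, so the size of this step in this assay is unknown. Given that compound 2, which also carries a chlorophenyl group, gives 62.3%, a step close to compound 1 is expected, with the estimated step from compound 1 to compound 4 being a number 4.3 percentage points higher from compound 1 to compound 4 (within the scatter), not clearly beyond the scatter in either direction. Compound 4 is therefore expected to give about 62% in this assay, within the range 45% to 78%.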

Compound 4, a percentage reported as inhibition, at one concentration (the size of the read-out at that concentration, not a potency): 75%
Compound 4: middle estimate off by 13 percentage points, on the low side, within the range that was stated.
By their numbers in this assay, from the lowest: compounds 1 and 2 (each within the scatter of the next); then compounds 4 and 3 (each within the scatter of the next).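

Going by these compounds alone, this is the first single change isolated: on an aromatic carbon of the five-membered aromatic ring with 3 nitrogen, 2-chlorophenyl in place of pyridin-3-yl gives a number 17.3 percentage points higher from compound 1 to compound 4 (beyond the scatter) in this assay. The position therefore responds to the group it carries, and inhibition at this concentration does not depend on the ring nitrogen or the hydrogen-bond acceptor counted on pyridin-3-yl. Nothing at hand accounts for the step.

The change swaps the ring and adds chlorine together, so the contribution of each remains unresolved; an unsubstituted phenyl at this place would separate them. Also open, from the compounds shown here alone, is how a methoxy group or an amine on this ring would compare with chlorine, and whether the step carries over to compounds with other groups elsewhere on the shared core.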